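The source may hold more compounds than are shown below. What is called first, only, known or untested is meant among the compounds shown, and "the series" means these compounds.

The measured compounds in a functional assay on L1210 cells (Mus musculus) for inhibition, read by cell counting, with a stated time of 48 h (on this read-out higher numbers stand for weaker inhibition and lower numbers for stronger inhibition), are these: compound 1 `CCN(CC)CN1C(=O)/C(=N/NC(=S)Nc2ccc(Cl)cc2)c2ccccc21` gives 11000 nM; compound 2 `CCN(CC)CN1C(=O)/C(=N/NC(=S)Nc2ccc(C)cc2)c2ccccc21` gives 29000 nM; compound 3 `CCN(CC)CN1C(=O)/C(=N/NC(=S)Nc2ccc(C)cc2)c2cc(Cl)ccc21` gives 9500 nM.

From compound 2 to compound 1 the change is chloro in place of methyl on an aromatic carbon and it made a 2.6-fold lower number from compound 2 to compound 1 (0.42 log units; beyond the scatter). The cores of compound 2 and compound 3 differ by chloro in place of hydrogen on an aromatic carbon, a change that made a 3.1-fold lower number from compound 2 to compound 3 (0.48 log units; beyond the scatter). Compound 3 and compound 1 give numbers that lie within the usual scatter of each other. Compound 4 `CCN(CC)CN1C(=O)/C(=N/NC(=S)Nc2ccc(Cl)cc2)c2cc(Cl)ccc21` differs from compound 3 by chloro in place of methyl on an aromatic carbon, which is the same change as that from compound 2 to compound 1, at a place described in the same words. Compound 4 is therefore expected to show a 2.4-fold lower number from compound 3 to compound 4 (0.38 log units; beyond the scatter), set beside the earlier step, because the same change gave a 2.6-fold lower number from compound 2 to compound 1 (0.42 log units; beyond the scatter). Compound 4 is estimated to give 4000 nM, most likely between 1500 nM and 10000 nM.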

Compound 4, half-maximal inhibitory concentration: > 125000 nM
Compound 4 ended at the assay's limit; the forecaster's own chance of this, stated with the estimate: 0%; middle value at least 31-fold (1.49 log units) away from the limit.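

In this assay compound 4 gives > 125000 nM, which is a limit of the assay and not a number. Chloro in place of methyl on an aromatic carbon gave an at least 13-fold higher number from compound 3 to compound 4 (1.11 log units; beyond the scatter), and chloro in place of hydrogen on an aromatic carbon gave an at least 11-fold higher number from compound 1 to compound 4 (1.05 log units; beyond the scatter), so neither change kept the direction it had on the other core: the same change on two cores in this assay, a 2.6-fold lower number (0.42 log units; beyond the scatter) from compound 2 to compound 1 and an at least 13-fold higher number (1.11 log units; beyond the scatter) from compound 3 to compound 4, at least 34-fold (1.54 log units) apart, beyond the scatter of two such steps. This shows that neither change can be carried from one core to another among these compounds, though it does not show why or how far compound 4 lies past the limit, and the second change parts just as widely: the same change on two cores in this assay, a 3.1-fold lower number (0.48 log units; beyond the scatter) from compound 2 to compound 3 and an at least 11-fold higher number (1.05 log units; beyond the scatter) from compound 1 to compound 4, at least 34-fold (1.54 log units) apart, beyond the scatter of two such steps.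

The compounds shown leave open whether the loss is tied to chloro alone. A fluoro or a methoxy group in place of either chloro of compound 4 might still give a measurable number in this assay.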